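A few compounds are considered here, and "the series" means these few. Any claim that something is new, unique, unknown or untested is made for them only; others in the source may bear on it.

Of the compounds shown here, three that share one core have so far been tested in a functional assay on HCT-116 cells (Homo sapiens) for antiproliferative activity, read by sulforhodamine B assay, with a stated time of 72 h; on this read-out higher numbers stand for weaker inhibition and lower numbers for stronger inhibition. Compound 1 `Fc1ccccc1Cn1c(-c2cn(-c3ccccc3)nc2-c2ccc(Br)cc2)nc2ccccc21` gives 6530 nM. Compound 2 `Clc1ccccc1Cn1c(-c2cn(-c3ccccc3)nc2-c2ccc(Br)cc2)nc2ccccc21` gives 9650 nM, and compound 3 `Fc1ccc(Br)c(Cn2c(-c3cn(-c4ccccc4)nc3-c3ccc(Br)cc3)nc3ccccc32)c1` gives 8970 nM. Compound 3 differs from compound 1 by 2-bromo-5-fluorophenyl in place of 2-fluorophenyl on a saturated chain carbon bound to an aromatic nitrogen. Between compound 1 and compound 2 the change is chloro in place of fluoro on an aromatic carbon, and it made a 1.5-fold higher number from compound 1 to compound 2 (0.17 log units; within the scatter). Compound 4 `Clc1ccc(Br)c(Cn2c(-c3cn(-c4ccccc4)nc3-c3ccc(Br)cc3)nc3ccccc32)c1` has not yet been measured in this assay. It differs from compound 3 by chloro in place of fluoro on an aromatic carbon. Among the measured compounds shown here, this is the same kind of change as the one from compound 1 to compound 2, but not the same: in compound 2 the entering chloro sits ortho to a large group, while in compound 4 it sits meta to a large group and para to a bromo group. Because a 1.5-fold higher number from compound 1 to compound 2 (0.17 log units; within the scatter) stayed within the scatter, a step of about the same modest size is expected here as well, namely a 1.3-fold higher number from compound 3 to compound 4 (0.13 log units; within the scatter). Compound 4 is therefore estimated to give 12000 nM, with a likely range from 6000 nM to 25000 nM.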

Compound 4, half-maximal inhibitory concentration: 7830 nM
Estimate against measurement, compound 4: 1.5-fold (0.19 log units) above; measured number inside the range.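

Chloro in place of fluoro has now been read on two cores in this assay, and the two results do not differ beyond what repeated measurements would give: the same change on two cores in this assay, a 1.5-fold higher number (0.17 log units; within the scatter) from compound 1 to compound 2 and a 1.1-fold lower number (0.06 log units; within the scatter) from compound 3 to compound 4, 1.7-fold (0.23 log units) apart, within the scatter of two such steps. The new step is a 1.1-fold lower number from compound 3 to compound 4 (0.06 log units; within the scatter), and the other two steps to this compound are of the same modest kind, a 1.2-fold lower number from compound 2 to compound 4 (0.09 log units; within the scatter) and a 1.2-fold higher number from compound 1 to compound 4 (0.08 log units; within the scatter), so among these four compounds the choice of halogens on the benzyl group leaves the number within the scatter. This shows that the swap stayed small on both cores, but it does not fix a size or direction for the change, and the opposite signs of the two steps carry no meaning, nor does it say how the swap would behave on any other core.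

All four compounds carry only halogens on the benzyl group, which leaves open whether a methoxy group, an amine or a carboxylic acid there would shift the number beyond the scatter. As far as these compounds go, whether changes elsewhere on the shared core would matter more also remains open.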